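This account rests on a few compounds, and the source may have more. Where it says the series, first, only, none or still open, it means among the compounds named here.

In an ADME assay on cells (Macrophage, Mus musculus) for cytotoxicity, read by resazurin assay, with a stated time of 3 days (a lower number here means a stronger inhibitor, a higher number a weaker inhibitor), compound 1 `NC(=O)c1cccc(NC(=O)c2cc(Cl)ccc2O)c1` gives > 60000 nM, which is a limit of the assay rather than a number. Compound 2 `O=C(Nc1ccc(S(=O)(=O)Nc2ccccc2)cc1)c1cc(Cl)ccc1O` likewise returns only a limit, > 60000 nM. Going by the values given here, compound 3 `O=C(Nc1cc(Br)cc(C(F)(F)F)c1)c1cc(F)ccc1O` is the one compound of the three with a numerical result in this assay, at 4700 nM. The other two values sit at the limit of > 60000 nM in this assay, at which 2 of the 3 values shown sit. Compound 4 `O=C(Nc1cccc(C(F)(F)F)c1)c1cc(F)ccc1O` has not yet been measured in this assay. It differs from compound 3 by hydrogen in place of bromo on an aromatic carbon. Among the compounds with values here, no measured pair follows this change, so its size is open; the expectation is a moderate weakening beyond the scatter, short of the limit. For compound 4 the estimated value in this assay is 15000 nM, with a range from 5000 nM to 60000 nM. The expected step from compound 3 to compound 4 is a 3.2-fold higher number from compound 3 to compound 4 (0.50 log units; beyond the scatter).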

Compound 4, half-maximal inhibitory concentration: 6100 nM
For compound 4 the middle estimate is 2.5-fold (0.39 log units) above the measured one; measured number inside the range.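

In this assay, going by these compounds alone, the change at this aromatic carbon, meta to a trifluoromethyl group, gives a 1.3-fold higher number from compound 3 to compound 4 (0.11 log units; within the scatter), the first one-place comparison. On this single pair, the reading does not depend on bromo at this position, and hydrogen serves equally well. Nothing measured here accounts for the size of this step.

As far as these compounds go, whether an amine, a methoxy group or a carboxylic acid at the same carbon would read alike remains open. So does the effect of replacing the trifluoromethyl group, which compound 3 and compound 4 share.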